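The source may hold more compounds than are shown below. What is called first, only, known or untested is meant among the compounds shown, and "the series" means these compounds.

Series notes. The shared core of compound 1 `NCc1ccc(C(=O)Nc2ccncc2F)cc1-c1cccc(C(=O)Nc2ccc(CC(=O)O)cc2)c1` carries, on the amide at its far end, a group that changes from compound to compound. In an assay on cells for inhibition of Rho-associated protein kinase 2 (Homo sapiens), read by radiometric assay and 33P incorporation, in the presence of a further agent that is not named here (on this read-out lower numbers stand for stronger inhibition and higher numbers for weaker inhibition), compound 1 gives 1.8 nM. Compound 3 `CCCCOC(=O)c1cccc(NC(=O)c2cccc(-c3cc(C(=O)Nc4ccncc4F)ccc3CN)c2)c1` in this assay gives 27 nM. Compound 2 `COC(=O)c1ccc(C(=O)Nc2cccc(-c3cc(C(=O)Nc4ccncc4F)ccc3CN)c2)cc1` in this assay gives only a limit, < 1 nM, and not a number. This limit is the one marked by the limit of < 1 nM in this assay, at which 1 of the 3 values shown sits, and compound 2 is the only one of the three measured compounds that stands at it. Among the measured compounds shown here, no two measured compounds differ in a single place, so no measured step is available.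

Compound 4 `COC(=O)c1ccc(F)c(C(=O)Nc2cccc(-c3cc(C(=O)Nc4ccncc4F)ccc3CN)c2)c1` is not yet measured. It differs from compound 2 by 2-fluoro-5-(methoxycarbonyl)phenyl in place of 4-(methoxycarbonyl)phenyl on a carbonyl carbon. With the reading for compound 2 being a limit, the step in this assay from compound 2 to compound 4 is expected to be a number no lower from compound 2 to compound 4 (the limit leaves the size open), which is no more than the usual scatter, in no firm direction. Compound 4 is therefore expected to give 1 nM in this assay, within a range from 0.3 nM to 4 nM, with a fair chance that the reading is again only a limit.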

Compound 4, half-maximal inhibitory concentration: < 1 nM
Compound 4 was reported as a limit; the forecaster's own chance of this, stated with the estimate: 40%; the middle value sits exactly at the limit.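

Compound 2 and compound 4 both stand as limits in this assay, so no step between them can be read: the limit of < 1 nM in this assay, at which 2 of the 4 values shown sit.

The compounds shown leave open whether 2-fluoro-5-(methoxycarbonyl)phenyl in place of 4-(methoxycarbonyl)phenyl on a carbonyl carbon changes inhibition at all, and in which direction.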